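Swapping the aryl group on the oxime carbon: compound 4

The source may report more compounds than this note shows. Statements on the series, on what has been measured and on what is new or still open speak of the compounds shown alone.

Measured so far:
- compound 1 `Cc1ccccc1/C(CCN1CCN(c2ccccn2)CC1)=N/O`: 82%
- compound 2 `O/N=C(\CCN1CCN(c2ccccn2)CC1)c1cccc(F)c1`: 72%
- compound 3 `Cc1cc(C)cc(/C(CCN2CCN(c3ccccn3)CC2)=N/O)c1`: 55%

All three share one core and differ only in the aromatic ring attached to the carbon with a double bond to nitrogen. In a functional assay on HEK293 cells with D(4) dopamine receptor (Homo sapiens) as the target, read by FLIPR (on this read-out higher numbers stand for larger maximal responses and lower numbers for smaller maximal responses), compound 1 gives the highest of the three numbers. Compound 2 lies close to it, a number 10 percentage points lower from compound 1 to compound 2 (within the scatter), so the two cannot be told apart. Compound 3 falls further, a number 27 percentage points lower from compound 1 to compound 3 (beyond the scatter) and a number 17 percentage points lower from compound 2 to compound 3 (beyond the scatter), a modest loss in both comparisons.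

Compound 4 `O/N=C(\CCN1CCN(c2ccccn2)CC1)c1ccc(F)cc1F` is not yet measured. Against compound 1 the change is 2,4-difluorophenyl in place of 2-methylphenyl on a carbon with a double bond to nitrogen. The step that bears most directly on it is the exchange of 2-methylphenyl for 3-fluorophenyl from compound 1 to compound 2, which stayed within the scatter; the drop to compound 3 shows that a second substituent on the ring can cost maximal response. Two fluorines are therefore expected to leave compound 4 somewhat lower than compound 1, a number 12 percentage points lower from compound 1 to compound 4 (beyond the scatter), an estimated value of 70% in this assay, with a range from 55% to 85%.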

Compound 4, largest response reached (reported as efficacy), in percent of the reference or control that the assay uses: 78%
For compound 4 the middle estimate is 8 percentage points below the measured one, within the range that was stated.
By their numbers in this assay, from the lowest: compound 3; then compounds 2, 4 and 1 (each within the scatter of the next).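

In this assay, the 2,4-difluorophenyl group holds the response level with both 2-methylphenyl (a number 4 percentage points lower from compound 1 to compound 4 (within the scatter)) and 3-fluorophenyl (a number 6 percentage points higher from compound 2 to compound 4 (within the scatter)). A ring with two substituents therefore need not lose maximal response: compound 4 has two fluorines where compound 3 has two methyl groups, and the 3,5-dimethylphenyl ring stands clearly apart (a number 23 percentage points higher from compound 3 to compound 4 (beyond the scatter)), so among these four compounds the loss appears only with compound 3. No measurement available here explains this difference between the two rings.

The compounds shown cannot tell whether the loss in compound 3 goes with the kind of substituent or with where the two groups sit on the ring. As far as these compounds go, how a ring carrying a methoxy group, a chlorine or an amine would behave at this carbon also stays open.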